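From a hydroxyl chain to a phenyl tail

A few compounds are considered here, and "the series" means these few. Any claim that something is new, unique, unknown or untested is made for them only; others in the source may bear on it.

Compound 1 `C[Se]c1nc(N)c2ccccc2n1` — 27600 nM
Compound 2 `CSc1nc(NCCCCCO)c2ccccc2n1` — > 100000 nM
Compound 3 `[SeH]c1nc([SeH])c2ccccc2n1` — 8980 nM

Of the compounds shown here, three sharing one core have been measured in a functional assay on HT-29 cells (Homo sapiens) for cytotoxicity, read by MTT assay, with a stated time of 72 h; a lower number here means a stronger inhibitor of growth, a higher number a weaker inhibitor of growth. Compound 1 gives 27600 nM and compound 3 gives 8980 nM. For compound 2 the value is only a limit of the assay, > 100000 nM, so it sits at the limit of > 100000 nM in this assay, at which 1 of the 3 values shown sits, and has no number of its own on the scale shown. No pair of these compounds differs in a single place, so no measured step is available to guide what follows.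

Compound 4 `CSc1nc(NCCCc2ccccc2)c2ccccc2n1` is the next compound to be measured in this assay. It differs from compound 2 as follows: phenyl in place of 2-hydroxyethyl on a saturated chain carbon, three bonds along the chain from a nitrogen on an aromatic ring. Since compound 2 stands only at a limit, the change from compound 2 to compound 4 cannot be sized against a measured number, and any expectation is loose. Compound 4 is expected to give roughly 60000 nM, within a range from 15000 nM to 200000 nM. The expected step is an at least 1.6-fold lower number from compound 2 to compound 4 (0.22 log units; that floor lies within the scatter), which would bring compound 4 modestly inside the measurable window, though a second limit is also quite possible.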

Compound 4, concentration for 50% growth inhibition: 19600 nM
Beside the measured number, compound 4's estimate is 3.1-fold (0.49 log units) above it, within the range that was stated.
By their numbers in this assay, from the lowest: compound 3; then compounds 4 and 1 (each within the scatter of the next). At a limit, above all of these: compound 2.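

In this assay, phenyl in place of 2-hydroxyethyl on a saturated chain carbon, three bonds along the chain from a nitrogen on an aromatic ring, gives an at least 5.1-fold lower number from compound 2 to compound 4 (0.70 log units; beyond the scatter). This is the only measured step among these compounds, and it shows that the chain at this position can carry measurable growth inhibition when it ends in phenyl rather than hydroxyl. The step is a floor and not a full size, because compound 2 stands at a limit of the assay: the limit of > 100000 nM in this assay, at which 1 of the 4 values shown sits.

The compounds shown do not separate the arrival of the phenyl from the loss of the hydroxyl; a chain ending in a methyl, an amine or a carboxylic acid would speak to that. Nor do they show what a longer chain carrying the same phenyl would give.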